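Changing the aryl group on a fused quinoline-type core

This account rests on a few compounds, and the source may have more. Where it says the series, first, only, none or still open, it means among the compounds named here.

Measured compounds:
compound 1 `O=S(=O)(c1ccc(F)c(F)c1)c1cnc2c(F)cccc2c1-c1cccc(F)c1` 1.28 mL/min
compound 2 `O=S(=O)(c1cc(F)cc(F)c1)c1cnc2c(F)cccc2c1-c1ccc(Cl)cc1` 0.73 mL/min

In an ADME assay on microsomes from liver (Homo sapiens) for metabolic stability, tested at 2.5 uM (a higher number here means faster removal of the compound, a lower number slower removal), compound 2 gives 0.73 mL/min, and compound 1 gives 1.28 mL/min; the two values lie within the usual scatter of each other, so neither stands apart. Compound 3 `O=S(=O)(c1cc(F)cc(F)c1)c1cnc2c(F)cccc2c1-c1cccc(F)c1` is not yet measured. It differs from compound 2 in one place: 3-fluorophenyl in place of 4-chlorophenyl on an aromatic carbon. Going by the values given here, with no measured pair showing this change, only a small step, if any, is expected beyond the scatter. Compound 3 is therefore estimated at 1 mL/min, between 0.5 mL/min and 2 mL/min, an expected step of a 1.4-fold higher number from compound 2 to compound 3 (0.14 log units; within the scatter).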

Compound 3, intrinsic clearance in a liver preparation (reported as CLH), per the amount of preparation that the assay uses: 1.18 mL/min
For compound 3 the middle estimate is 1.2-fold (0.07 log units) below the measured one, and the stated range covers the measured number.
By their numbers in this assay, from the lowest: compounds 2, 3 and 1 (each within the scatter of the next).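

In this assay, 3-fluorophenyl in place of 4-chlorophenyl on the aromatic carbon gives a 1.6-fold higher number from compound 2 to compound 3 (0.21 log units; within the scatter), so this swap at this position cannot be told from repeat-measurement noise. On the sulfonyl sulfur, 3,5-difluorophenyl in place of 3,4-difluorophenyl gives a 1.1-fold lower number from compound 1 to compound 3 (0.04 log units; within the scatter), and that step is just as unresolved. Nothing available here accounts for either step. The first swap alters both the halogen and its place on the ring, and these two changes remain unseparated. Going by these compounds, whether an amine or a carboxylic acid on that phenyl ring would give a step beyond the scatter also remains open.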